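Branching the alkyl on the aromatic nitrogen

This account rests on a few compounds, and the source may have more. Where it says the series, first, only, none or still open, it means among the compounds named here.

Among the compounds with values here, compound 1 `CCCn1ncnc1-c1ccccc1NCC1=NCCN1` is the only member of the series with a numerical result: in an in vitro functional assay on cells (Fibroblast) for agonist activity at Alpha-1D adrenergic receptor (Homo sapiens) (on this read-out higher numbers stand for an effect only at larger amounts of compound and lower numbers for an effect already at smaller amounts), compound 1 gives 251 nM. Compound 2 `Cn1nccc1-c1ccccc1NCC1=NCCN1` reaches only a limit of the assay, < 100000 nM in this assay (the limit of < 100000 nM in this assay, at which 1 of the 2 values shown sits). Compound 3 `CC(C)n1ncnc1-c1ccccc1NCC1=NCCN1` differs from compound 1 by isopropyl in place of propyl on an aromatic nitrogen. Within the data shown here, no step between measured compounds differing in one place exists here, so the size of the change is open; the same atoms joined differently at this place are expected to move potency little, within the scatter. Compound 3 is estimated to give 300 nM in this assay, in the range 100 nM to 1000 nM. The expected step is a 1.2-fold higher number from compound 1 to compound 3 (0.08 log units; within the scatter), within the scatter.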

Compound 3, half-maximal effective concentration: 3160 nM
Compound 3: middle estimate off by 11-fold (1.02 log units), on the low side; measured number above the stated range.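

Isopropyl in place of propyl on the aromatic nitrogen gives a 13-fold higher number from compound 1 to compound 3 (1.10 log units; beyond the scatter) and so shows that this position separates two chains built from the same atoms. Branching alone, with the heavy-atom count unchanged, is enough for a step of this size, and the number is lower with the straight propyl chain.

Going by these compounds, whether ethyl, butyl or cyclopropyl at this position stays close to compound 1 or moves towards compound 3 remains open. Nothing in the data shown accounts for the step.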